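Pyridinyl Sulfonamide Swap in a Muscarinic M5 Modulator Series

A few compounds are considered here, and "the series" means these few. Any claim that something is new, unique, unknown or untested is made for them only; others in the source may bear on it.

Measured so far in a functional assay on CHO cells for positive allosteric modulation of muscarinic acetylcholine receptor M5 (Homo sapiens), read by calcium flux; on this read-out lower numbers stand for an effect already at smaller amounts and higher numbers for an effect only at larger amounts of compound:
Compound 1 `CCN(Cc1ccccc1)C(=O)C1CCN(S(=O)(=O)c2cccc(OC)c2)CC1` gives 3090 nM; 3100 nM (2 entries).
Compound 2 `CCN(Cc1ccccc1)C(=O)C1CCN(S(=O)(=O)c2ccc(C)s2)CC1` gives > 10000 nM; > 10000 nM (2 entries), a limit of the assay rather than a number.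
Compound 3 `CCN(Cc1ccccc1)C(=O)C1CCN(S(=O)(=O)c2c(C)noc2C)CC1` gives > 10000 nM, likewise a limit of the assay.

Among the measured compounds shown here, compound 1 is the only one with a measured number, and its repeat entries agree closely (the several entries of compound 1 in this assay, 3090 nM; 3100 nM (2 entries)). Compound 3 stands at the limit (the limit of > 10000 nM in this assay, at which 1 of the 3 values shown sits), with further entries that also give no single number. Compound 4 `CCN(Cc1ccccc1)C(=O)C1CCN(S(=O)(=O)c2ccncc2)CC1` carries pyridin-4-yl in place of 3,5-dimethyl-1,2-oxazol-4-yl on a sulfonyl sulfur. For the measured compounds named here, no step between measured compounds is available to guide this change, so its size in this assay is open; the step from compound 3 to compound 4 is expected to be an at least 1.2-fold lower number from compound 3 to compound 4 (0.09 log units; that floor lies within the scatter), though a further limit or no effect beyond the scatter is equally plausible. Compound 4 is therefore estimated at about 8000 nM, within 2500 nM to 30000 nM.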

Compound 4, half-maximal effective concentration: > 10000 nM
Compound 4 ended at the assay's limit; the forecaster's own chance of this, stated with the estimate: 50%; middle value at least 1.2-fold (0.09 log units) from the limit.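

Compound 3 and compound 4 both end at a limit rather than a number, and the step between them cannot be read. As far as these compounds go, whether pyridin-4-yl changes anything compared with 3,5-dimethyl-1,2-oxazol-4-yl stays open.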